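Replacing the Amine Arm with a Short Alcohol

The compounds below may be only part of what the source reports. "The series", "measured", "known", "first", "only" and "open" are said of these compounds alone.

Measured so far, in a functional assay on DLD-1 cells (Homo sapiens) for inhibition, read by MTT assay, with a stated time of 72 h; on this read-out lower numbers stand for stronger inhibition and higher numbers for weaker inhibition:
- compound 1, `COc1ccc(CCCNCc2c(OC)cc(Oc3cccc(Nc4ccccc4)c3)cc2OC)cc1`, gives 2540 nM
- compound 2, `COc1cc(Oc2cccc(Nc3ccccc3)c2)cc(OC)c1CN[C@H](C)c1ccccc1`, gives 8570 nM

Compound 2 holds the highest of the two numbers in this assay; its nearest neighbour is compound 1, and the step of a 3.4-fold higher number from compound 1 to compound 2 (0.53 log units; beyond the scatter), which came from putting 1-phenylethyl in place of 3-(4-methoxyphenyl)propyl on the amine nitrogen, shows that changing the group on that nitrogen moves the number modestly. Compound 3, `COc1cc(Oc2cccc(Nc3ccccc3)c2)cc(OC)c1CCO`, goes further: the change is hydroxymethyl in place of (1-phenylethyl)amino on a saturated chain carbon bound to an aromatic carbon, so the amine nitrogen and its attached ring disappear altogether and only a hydroxymethyl remains on the saturated chain carbon bound to an aromatic carbon. For the measured compounds named here, only the step from compound 1 to compound 2 bears on this, and it tells of a change at the nitrogen, not its removal. A further weakening is nevertheless expected, so compound 3 is estimated at 15000 nM, with a range from 4000 nM to 50000 nM, a step of a 1.8-fold higher number from compound 2 to compound 3 (0.24 log units; within the scatter) in this assay.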

Compound 3, half-maximal inhibitory concentration: 18100 nM
Compound 3: the middle estimate sits 1.2-fold (0.08 log units) below what was measured, within the range that was stated.
By their numbers in this assay, from the lowest: compound 1; then compound 2; then compound 3.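

Taking away the amine nitrogen and its attached ring, with hydroxymethyl in place of (1-phenylethyl)amino, weakens inhibition further in this assay and gives a 2.1-fold higher number from compound 2 to compound 3 (0.32 log units; beyond the scatter) on this change. Measured against the longer arm, the replacement gives a 7.1-fold higher number from compound 1 to compound 3 (0.85 log units; beyond the scatter) and is the largest step among these compounds, so this position tolerates the loss of the whole arm only at a clear cost in potency, though compound 3 still gives a measured number. Nothing available here explains these shifts.

From the compounds shown here alone, compound 3 loses the nitrogen and the ring together, so their separate contributions remain unknown. A simple primary amine on the same saturated chain carbon would keep the nitrogen without the ring, while a carboxylic acid there would test a different replacement for the arm.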